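Swapping the benzylic aryl group in a triazole-linked indole sulfonamide

The source may report more compounds than this note shows. Statements on the series, on what has been measured and on what is new or still open speak of the compounds shown alone.

The two measured compounds share a core carrying a tosyl-protected indole nitrogen and a triazole linked through a saturated carbon to a benzyl group. Compound 1 `Cc1ccc(S(=O)(=O)N(Cc2cn(Cc3ccc(F)cc3)nn2)Cc2c(-c3ccccc3)c3ccccc3n2S(=O)(=O)c2ccc(C)cc2)cc1` is the reference point. In a functional assay on 3T3-L1 cells (Mus musculus) for inhibition, with a stated time of 20 min, tested at 20 uM (on this read-out higher numbers stand for more inhibition at the one concentration tested (going by the name of the read-out) and lower numbers for less inhibition), compound 1 gives -7.6%. Its companion compound 2 `Cc1ccc(S(=O)(=O)n2c(CN(Cc3cn(Cc4ccc(F)cc4F)nn3)S(C)(=O)=O)c(C)c3ccccc32)cc1` gives -20.8% in this assay. Compound 1 therefore stands highest of the two numbers, and compound 2 sits lower by a gap that is beyond the scatter; still, neither number indicates inhibition at the concentration tested.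

Compound 3 `COc1cc(Cn2cc(CN(Cc3c(-c4ccccc4)c4ccccc4n3S(=O)(=O)c3ccc(C)cc3)S(=O)(=O)c3ccc(C)cc3)nn2)cc(OC)c1OC` has not yet been measured. It differs from compound 1 in one place: 3,4,5-trimethoxyphenyl in place of 4-fluorophenyl on a saturated chain carbon bound to an aromatic nitrogen. For the measured compounds named here, no pair of measured compounds that differ in exactly one place is available, so the size of this step cannot be read from the data.

Since compound 1 shows -7.6% and compound 2 shows -20.8%, neither being in the range of real inhibition, compound 3 is expected to behave similarly, with a step of a number 3.6 percentage points higher from compound 1 to compound 3 (within the scatter) that is expected to stay within the scatter. Compound 3 is thus estimated to give -4% in this assay, expected to fall between -22% and 14%.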

Compound 3, a percentage reported as inhibition, at one concentration (the size of the read-out at that concentration, not a potency): -10.9%
For compound 3 the middle estimate is 6.9 percentage points above the measured one; low and high end bracket the measured number.
By their numbers in this assay, from the lowest: compounds 2, 3 and 1 (each within the scatter of the next, the first and the last beyond it).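

For the compounds shown here, the reading in this assay for the exchange of 4-fluorophenyl for 3,4,5-trimethoxyphenyl on a saturated chain carbon bound to an aromatic nitrogen is a number 3.3 percentage points lower from compound 1 to compound 3 (within the scatter) and gives the first direct look at this position. The entering group has 12 heavy atoms against 7 and 3 hydrogen-bond acceptors against 0, yet this larger change in the group does not separate the two compounds, and compound 3 at -10.9% shows no inhibition at the one concentration tested, as is also the case for compound 1. Nothing available here accounts for this outcome.

Going by these compounds alone, compound 2 differs from compound 1 and from compound 3 in more than one place, so no steps to it can be read. The compounds shown leave open whether a group of another kind at this place, such as an amine, a carboxylic acid or a longer chain, would bring the read-out into the range of real inhibition, or whether this position simply has no bearing on it.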